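Compound 3 to compound 4: 2,5-dihydroxyphenyl enters

The compounds below may be only part of what the source reports. "The series", "measured", "known", "first", "only" and "open" are said of these compounds alone.

In a functional assay on SW982 cells (Homo sapiens) for inhibition, read by MTT assay, with a stated time of 72 h (on this read-out higher numbers stand for weaker inhibition and lower numbers for stronger inhibition), compound 1 (`COc1cc(OC)c(OC)cc1/C=C/C(=O)c1ccc(Cl)cc1`) gives 58500 nM, compound 2 (`COc1ccc(C(=O)/C=C/c2cc(OC)c(OC)cc2OC)cc1`) gives 60500 nM and compound 3 (`COc1cc(OC)c(OC)cc1/C=C/C(=O)c1ccc(C)cc1`) gives 81100 nM, so compound 3 stands level with the other two within the scatter. Compound 4 (`COc1cc(OC)c(OC)cc1/C=C/C(=O)c1cc(O)ccc1O`) carries 2,5-dihydroxyphenyl in place of 4-methylphenyl on a carbonyl carbon. The closest measured steps each swap one group on an aromatic carbon: a 1.0-fold higher number from compound 1 to compound 2 (0.01 log units; within the scatter), a 1.4-fold higher number from compound 1 to compound 3 (0.14 log units; within the scatter) and a 1.3-fold higher number from compound 2 to compound 3 (0.13 log units; within the scatter). All stay within the scatter, yet none involves 2,5-dihydroxyphenyl, so they guide this larger swap only loosely. A modest move toward a lower number is expected, possibly no more than scatter. The expected size is a 1.8-fold lower number from compound 3 to compound 4 (0.26 log units; within the scatter). For compound 4, the estimated value is 45000 nM, with an expected range from 15000 nM to 100000 nM.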

Compound 4, half-maximal inhibitory concentration: > 150000 nM
Compound 4 ended at the assay's limit; the forecaster's own chance of this, stated with the estimate: 5%; at least 3.3-fold (0.52 log units) between middle value and limit.
By their numbers in this assay, from the lowest: compounds 1, 2 and 3 (each within the scatter of the next). At a limit, above all of these: compound 4.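

In this assay, going by these compounds alone, placing 2,5-dihydroxyphenyl on the carbonyl carbon gives the first change here that moves beyond the scatter, with an at least 2.4-fold higher number from compound 2 to compound 4 (0.39 log units; beyond the scatter) and an at least 2.5-fold higher number from compound 1 to compound 4 (0.40 log units; beyond the scatter). The third comparison is less firm, with an at least 1.8-fold higher number from compound 3 to compound 4 (0.26 log units; that floor lies within the scatter). Compound 4 stands at a limit, so all three steps are floors and their full size stays unknown: the limit of > 150000 nM in this assay, at which 1 of the 4 values shown sits.

The compounds shown leave open whether a single hydroxyl group on that aromatic ring would give the same loss of inhibition. They also leave open how an amine or a carboxylic acid there would read.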